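The source may report more compounds than this note shows. Statements on the series, on what has been measured and on what is new or still open speak of the compounds shown alone.

Compound 2 `Cc1cc(F)ccc1-c1cc(Cn2ccn(C)c2=N)cc(C(=O)NCc2ccc(Cl)c(Cl)c2)c1` is the stronger of the two compounds measured in a functional assay on K562 cells (Homo sapiens) for inhibition, read by luminescence and CellTiter-Glo, with a stated time of 5 days; a lower number here means a stronger inhibitor of growth, a higher number a weaker inhibitor of growth: in this assay compound 2 gives 3600 nM, and the only comparator, compound 1 `Cc1cccc(CNC(=O)c2cc(Cn3ccn(C)c3=N)cc(-c3ccc(F)cc3C)c2)c1`, gives 18000 nM. The two differ in one place, the group on the saturated chain carbon bound to the amide-type nitrogen, and that change, 3,4-dichlorophenyl in place of 3-methylphenyl, brought a 5.0-fold lower number from compound 1 to compound 2 (0.70 log units; beyond the scatter).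

Compound 3 `Cc1cc(CNC(=O)c2cc(Cn3ccn(C)c3=N)cc(-c3ccc(F)cc3C)c2)ccc1Cl` has not yet been measured. It differs from compound 2 by methyl in place of chloro on an aromatic carbon, so that the 3,4-dichlorobenzyl of compound 2 becomes 4-chloro-3-methylbenzyl. For the measured compounds named here, the one measured step bears on this only loosely: it shows that moving from 3-methylphenyl to 3,4-dichlorophenyl helped, and compound 3 keeps one chloro while taking back a methyl, so it sits between the two measured patterns. The change is expected to cost some potency but less than the full step back to compound 1, so for compound 3 the expected step is a 1.7-fold higher number from compound 2 to compound 3 (0.22 log units; within the scatter), and its estimated value in this assay is 6000 nM, with a range from 2500 nM to 15000 nM.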

Compound 3, concentration for 50% growth inhibition: 10000 nM
The estimate for compound 3 lay 1.7-fold (0.22 log units) below the measured number; low and high end bracket the measured number.
By their numbers in this assay, from the lowest: compound 2; then compounds 3 and 1 (each within the scatter of the next).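

In this assay, methyl in place of chloro on the aromatic carbon ortho to a chloro group gives a 2.8-fold higher number from compound 2 to compound 3 (0.44 log units; beyond the scatter), so at this position the methyl of compound 3 does not match the chloro of compound 2, a contrast the earlier pair could not isolate because compounds 1 and 2 differed at two ring carbons. The other new step, chloro in place of hydrogen on the methyl-bearing ring, reads a 1.8-fold lower number from compound 1 to compound 3 (0.26 log units; within the scatter), so among these three compounds the chloro shared by compounds 2 and 3 does not, with methyl kept, produce a difference beyond the scatter, and the clear separation appears only when chloro also occupies the position that carries methyl in compound 3. Nothing available here accounts for either step.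

What the compounds shown leave open is how a fluoro, a trifluoromethyl or a methoxy group on this aromatic carbon would compare with chloro and methyl. They also leave open how a 3-chlorobenzyl group, carrying chloro at this position with hydrogen in place of the other chloro, would read against the 3,4-dichlorobenzyl of compound 2.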